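The source may report more compounds than this note shows. Statements on the series, on what has been measured and on what is new or still open speak of the compounds shown alone.

For the measured compounds named here, in a functional assay on EBC-1 cells (Homo sapiens) for antiproliferative activity, read by sulforhodamine B assay, with a stated time of 72 h (a higher number here means a weaker inhibitor, a lower number a stronger inhibitor), compound 1 `Cn1cc(-c2ccc(=O)n(CCOc3ccnc4cc(OCCCCCC(=O)NO)ccc34)n2)cn1` gives 460 nM, the higher of the two numbers so far. Compound 2 `Cn1cc(-c2ccc(=O)n(CCOc3ccnc4cc(OCc5ccc(/C=C/C(=O)Nc6ccccc6N)nc5)ccc34)n2)cn1` gives 46 nM. The gap between these two compounds lies beyond the scatter. Compound 3 `Cn1cc(-c2ccc(=O)n(CCOc3ccnc4cc(C(=O)Nc5ccccc5N)ccc34)n2)cn1` has (2-aminophenyl)carbamoyl in place of (5-(hydroxycarbamoyl)pentyl)oxy on an aromatic carbon. Going by the values given here, no measured pair isolates this change, so any expectation in this assay is loose. A moderate step towards a lower number is expected, resting on compound 2, which also carries that group and gives 46 nM. The estimated change is a 2.1-fold lower number from compound 1 to compound 3 (0.32 log units; beyond the scatter). For compound 3 the expected value is 220 nM, within an estimated range of 50 nM to 900 nM.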

Compound 3, half-maximal inhibitory concentration: > 10000 nM
Compound 3 gave a limit, no number; the forecaster's own chance of this, stated with the estimate: 3%; middle value at least 45-fold (1.65 log units) away from the limit.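

Compound 3 reads only as a limit in this assay, not as a number: the limit of > 10000 nM in this assay, at which 1 of the 3 values shown sits. The exchange of (5-(hydroxycarbamoyl)pentyl)oxy for (2-aminophenyl)carbamoyl on this aromatic carbon gives an at least 21-fold higher number from compound 1 to compound 3 (1.33 log units; beyond the scatter), so this position is sensitive to the group it carries, even though both groups count the same heavy atoms. The (2-aminophenyl)carbamoyl group set directly on the ring therefore does not keep the activity of compound 1 in this assay. Open, on these data alone, is whether a longer chain ending in (2-aminophenyl)carbamoyl, or a simple carboxylic acid or amine at this carbon, would give a measurable value.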